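The source may hold more compounds than are shown below. What is called first, only, known or untested is meant among the compounds shown, and "the series" means these compounds.

Measured compounds in the series:

compound 1, `Cc1ccccc1/C(CCN1CCN(c2ccccn2)CC1)=N/O` — 82%
compound 2, `O/N=C(\CCN1CCN(c2ccccn2)CC1)c1cc(F)cc(F)c1` — 74%

In a functional assay on HEK293 cells with D(4) dopamine receptor (Homo sapiens) as the target, read by FLIPR (on this read-out lower numbers stand for smaller maximal responses and higher numbers for larger maximal responses), compound 2 gives 74%, the lower of the two numbers measured; its nearest neighbour is compound 1 at 82%, and the step of a number 8 percentage points lower from compound 1 to compound 2 (within the scatter) stays within the scatter. Compound 3, `O/N=C(\CCN1CCN(c2ccccn2)CC1)c1ccc(F)cc1F`, is the next compound for this assay. It differs from compound 2 by 2,4-difluorophenyl in place of 3,5-difluorophenyl on a carbon with a double bond to nitrogen. Among the compounds with values here, the one measured step bearing on this place is the aryl exchange on the same carbon with a double bond to nitrogen, which gave a number 8 percentage points lower from compound 1 to compound 2 (within the scatter); no measured pair moves the two fluorine atoms around the ring, so that comparison is missing. On these numbers the expected step in this assay is none beyond the scatter, with compound 3 expected to land close to compound 2. Compound 3 is therefore estimated at 76%, with a range of 62% to 90%. The expected step is a number 2 percentage points higher from compound 2 to compound 3 (within the scatter).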

Compound 3, largest response reached (reported as efficacy), in percent of the reference or control that the assay uses: 78%
For compound 3 the middle estimate is 2 percentage points below the measured one, and the stated range covers the measured number.
By their numbers in this assay, from the lowest: compounds 2, 3 and 1 (each within the scatter of the next).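

In this assay, within the data shown here, rearranging the two fluorine atoms, with 2,4-difluorophenyl in place of 3,5-difluorophenyl on the carbon with a double bond to nitrogen, gives (a number 4 percentage points higher from compound 2 to compound 3 (within the scatter)), the first measured pair in which the aryl group keeps the same atoms and changes only in how they are joined. With 2,4-difluorophenyl in place of 2-methylphenyl at this same place, the step is (a number 4 percentage points lower from compound 1 to compound 3 (within the scatter)), so the three aryl groups shown all lie within the scatter of one another. No supporting data are available to account for these numbers.

Still open, on these data alone, is whether the maximal response stays in this range with an amine or a carboxylic acid on the aryl ring. As far as these compounds go, the effect of a longer chain in place of the saturated chain on this carbon is also open.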